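The compounds below may be only part of what the source reports. "The series", "measured", "known", "first", "only" and "open" are said of these compounds alone.

In an ADME assay (liver) for metabolic stability, with Liver microsome (Rattus norvegicus) as the target, using microsomes (on this read-out lower numbers stand for slow clearance and higher numbers for fast clearance), compound 2 (`Cc1nc2c(s1)CC[C@H]2C(=O)Nc1ccc(C[C@@H]2CC[C@H]([C@H](O)c3ccccc3)N2)cc1`) gives 135 mL/min/kg and holds the higher of the two measured numbers, with compound 1 (`Nc1nc2c(s1)CCC[C@H]2C(=O)Nc1ccc(C[C@@H]2CC[C@H]([C@H](O)c3ccccc3)N2)cc1`) at 63 mL/min/kg in the same read-out. The change to compound 3 (`Nc1nc2c(s1)CC[C@H]2C(=O)Nc1ccc(C[C@@H]2CC[C@H]([C@H](O)c3ccccc3)N2)cc1`) is amino in place of methyl on an aromatic carbon and amounts to amino in place of methyl on an aromatic carbon. Within the data shown here, only one measured step bears on it: a 2.1-fold higher number from compound 1 to compound 2 (0.33 log units; beyond the scatter) is modest, and it alters the fused non-aromatic ring as well as this group. As far as these compounds go, compound 3 keeps the amino of compound 1 and the five-membered non-aromatic ring of compound 2, so the share of that step tied to amino alone is unknown. With that single step as a guide, a 1.6-fold lower number from compound 2 to compound 3 (0.20 log units; within the scatter) is expected in this assay as a move to a lower number that may not clear the scatter. For compound 3 the estimate is 85 mL/min/kg with an expected range from 45 mL/min/kg to 150 mL/min/kg in this read-out.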

Compound 3, clearance: 59 mL/min/kg
Beside the measured number, compound 3's estimate is 1.4-fold (0.16 log units) above it; the measured number falls inside the stated range.
By their numbers in this assay, from the lowest: compounds 3 and 1 (each within the scatter of the next); then compound 2.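

In this assay, amino in place of methyl on the aromatic carbon alone gives a 2.3-fold lower number from compound 2 to compound 3 (0.36 log units; beyond the scatter), so this change by itself moves the clearance number beyond the scatter, which the earlier step, with its altered fused ring, could not show. With amino held constant, the five-membered non-aromatic ring in place of the six-membered one gives a 1.1-fold lower number from compound 1 to compound 3 (0.03 log units; within the scatter), leaving that pair within the scatter of each other. Nothing at hand gives a reason for either step.

As far as these compounds go, whether the lower number is particular to amino stays open; a hydroxyl, a chlorine or a methylamino on the same aromatic carbon would test it. Also open, from the compounds shown here alone, is whether methyl to amino gives a step of similar size on the six-membered non-aromatic ring.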